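From Methoxyphenyl to Pyridinyl: An Expectation for Compound 4

This account rests on a few compounds, and the source may have more. Where it says the series, first, only, none or still open, it means among the compounds named here.

Compound 1 `COc1nc(-c2ccccc2)cc(-c2ccc(Cl)cc2Cl)c1C#N` gives 5340 nM in a functional assay on trachea (Cavia porcellus) for activation; a higher number here means a weaker inhibitor, a lower number a stronger inhibitor. Compound 2 `COc1nc(-c2ccc(C)cc2)cc(-c2ccc(Cl)cc2Cl)c1C#N` gives 10600 nM in this assay. Compound 3 `COc1ccc(-c2cc(-c3ccc(Cl)cc3Cl)c(C#N)c(OC)n2)cc1` gives 9890 nM in this assay.

Compound 3 sits among the three measured compounds with its number within the scatter of both neighbours: the step of a 1.9-fold higher number from compound 1 to compound 3 (0.27 log units; within the scatter) and the step of a 1.1-fold lower number from compound 2 to compound 3 (0.03 log units; within the scatter) are both within the scatter, so no ordering among compounds 1, 2 and 3 can be read from this assay.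

Compound 4 `COc1nc(-c2ccncc2)cc(-c2ccc(Cl)cc2Cl)c1C#N` differs from compound 3 in one place: pyridin-4-yl in place of 4-methoxyphenyl on an aromatic carbon. Within the data shown here, no measured step swaps a carbon ring for a ring bearing a nitrogen; the steps that bear on this position are a 2.0-fold higher number from compound 1 to compound 2 (0.30 log units; within the scatter) and a 1.9-fold higher number from compound 1 to compound 3 (0.27 log units; within the scatter), and both stayed within the scatter. On that basis the step of a 1.2-fold lower number from compound 3 to compound 4 (0.09 log units; within the scatter) is expected to be small, with no direction beyond the scatter. Compound 4 is therefore estimated at 8000 nM in this assay, in a range from 2500 nM to 25000 nM.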

Compound 4, half-maximal inhibitory concentration: 11800 nM
The estimate for compound 4 lay 1.5-fold (0.17 log units) below the measured number; the measured number falls inside the stated range.
By their numbers in this assay, from the lowest: compounds 1, 3, 2 and 4 (each within the scatter of the next, the first and the last beyond it).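

Among these compounds, compound 4 puts a ring nitrogen at this position for the first time, and in this assay the steps of a 1.2-fold higher number from compound 3 to compound 4 (0.08 log units; within the scatter) and a 1.1-fold higher number from compound 2 to compound 4 (0.05 log units; within the scatter) both stay within the scatter, so pyridin-4-yl cannot be told apart from 4-methoxyphenyl or 4-methylphenyl here. Only against the plain phenyl of compound 1 does a change at this position pass the scatter, and the step of a 2.2-fold higher number from compound 1 to compound 4 (0.34 log units; beyond the scatter) remains modest. Nothing available explains this small step.

The compounds shown leave open whether pyridin-3-yl, or a phenyl ring bearing an amine or a carboxylic acid, would shift the number in this assay by more than these steps. They also leave open how far changes to the 2,4-dichlorophenyl, methoxy or cyano groups on the shared core would move it.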